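Replacing an Aromatic End Group on Compound 1

The compounds below may be only part of what the source reports. "The series", "measured", "known", "first", "only" and "open" are said of these compounds alone.

In a functional assay on COLO 205 cells (Homo sapiens) for inhibition, read by sulforhodamine B assay, with a stated time of 48 h, tested at 50 uM (on this read-out lower numbers stand for less inhibition of growth and higher numbers for more inhibition of growth at the one concentration tested), compound 1 (`COc1ccc(/C=C/C(=O)/C=C/c2ccc(OCc3cn(CCCCCOc4cc(=O)oc5ccccc45)nn3)c(OC)c2)cc1OC`) gives 43% as the lowest of three numbers. Compound 2 (`COc1cc(/C=C/C(=O)/C=C/c2cc(OC)c(OC)c(OC)c2)ccc1OCc1cn(CCOc2cc(=O)oc3ccccc23)nn1`) gives 86% and compound 3 (`COc1ccc(/C=C/C(=O)/C=C/c2ccc(OCc3cn(CCOc4cc(=O)oc5ccccc45)nn3)c(OC)c2)cc1OC`) gives 80% on the same read-out, and both lie well clear of compound 1.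

Compound 4 (`COc1cc(/C=C/C(=O)/C=C/c2ccco2)ccc1OCc1cn(CCCCCOc2cc(=O)oc3ccccc23)nn1`) carries furan-2-yl in place of 3,4-dimethoxyphenyl (furan-2-yl in place of 3,4-dimethoxyphenyl on a double-bonded chain carbon bound to a double-bonded chain carbon) on a double-bonded chain carbon bound to a double-bonded chain carbon.

For the measured compounds named here, the one measured step (a number 6 percentage points lower from compound 2 to compound 3 (within the scatter)) puts hydrogen in place of methoxy on an aromatic carbon and stays within the scatter. It is a much smaller change, so it guides only weakly. The expected step (a number 2 percentage points higher from compound 1 to compound 4 (within the scatter)) is therefore no more than the scatter. Compound 4 is expected at 45% (estimated range 25% to 65%).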

Compound 4, percent growth inhibition at one concentration: 33%
Estimate against measurement, compound 4: 12 percentage points above, and the stated range covers the measured number.
By their numbers in this assay, from the lowest: compounds 4 and 1 (each within the scatter of the next); then compounds 3 and 2 (each within the scatter of the next).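

At this position, on a double-bonded chain carbon bound to a double-bonded chain carbon, furan-2-yl in place of 3,4-dimethoxyphenyl gives a number 10 percentage points lower from compound 1 to compound 4 (within the scatter) in this assay. An end group of 5 heavy atoms with a five-membered aromatic ring can therefore stand where one of 10 heavy atoms stood, with no difference this read-out can separate from scatter. No evidence here bears on why the two groups read alike. From the compounds shown here alone, whether an end group carrying an amine or a carboxylic acid would read differently here stays open, as does whether furan-2-yl would read alike on compound 3.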